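Removal of the methoxy from the pendant phenyl ring

A few compounds are considered here, and "the series" means these few. Any claim that something is new, unique, unknown or untested is made for them only; others in the source may bear on it.

Measured compounds in a functional assay on A549 cells (Homo sapiens) for antiproliferative activity, read by MTT assay, with a stated time of 24 h; on this read-out lower numbers stand for stronger inhibition and higher numbers for weaker inhibition:
compound 1, `C=CCc1cc(-c2ccccc2C(F)(F)F)ccc1O`, 59700 nM
compound 2, `C=CCc1cc(-c2cccc(C(F)(F)F)c2)ccc1O`, 73000 nM
compound 3, `C=CCc1cc(-c2cccc(OC)c2)ccc1O`, > 100000 nM

For the measured compounds named here, compound 3 shows only a limit of the assay, > 100000 nM, and no number; it is the one value of the three at the limit of > 100000 nM in this assay, at which 1 of the 3 values shown sits. Compound 1 and compound 2 give numbers that lie within the scatter of each other. Going by the values given here, the one step among measured compounds, methoxy in place of trifluoromethyl on an aromatic carbon, gives an at least 1.3-fold higher number from compound 2 to compound 3 (0.13 log units; that floor lies within the scatter), and its floor is inside the scatter, so it shows no change that can be relied on.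

Compound 4, `C=CCc1cc(-c2ccccc2)ccc1O`, is not yet measured. It differs from compound 3 by hydrogen in place of methoxy on an aromatic carbon. Among the compounds with values here, no measured step changes a substituent to hydrogen, so the only bearing comes from compound 2 and compound 3, where a switch of the group on that aromatic carbon moved the number by no more than the scatter. The step from compound 3 to compound 4 is therefore expected to be small as well, and in this assay compound 4 is expected to give 100000 nM, within 50000 nM to 200000 nM, with a fair chance of another limit; the expected step is a number no higher from compound 3 to compound 4 (the limit leaves the size open).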

Compound 4, half-maximal inhibitory concentration: > 100000 nM
Compound 4 gave a limit, no number; the forecaster's own chance of this, stated with the estimate: 50%; the middle value lies on the limit itself.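

Taking the methoxy away does not bring back a readable number in this assay: compound 4, like compound 3, stays at a limit and gives no number, so the step between these two cannot be read. Hydrogen in place of trifluoromethyl gives an at least 1.3-fold higher number from compound 2 to compound 4 (0.13 log units; that floor lies within the scatter) and an at least 1.6-fold higher number from compound 1 to compound 4 (0.22 log units; that floor lies within the scatter), and with both floors inside the scatter, no loss on removing trifluoromethyl can be relied on. So far only the two trifluoromethyl compounds, compound 1 and compound 2, give numbers, while the methoxy and hydrogen compounds both sit at the limit of the read-out: the limit of > 100000 nM in this assay, at which 2 of the 4 values shown sit.

Where compound 3 and compound 4 truly lie remains unknown, so methoxy, hydrogen and trifluoromethyl cannot yet be put in an order on this aromatic carbon. Also open, from the compounds shown here alone, is whether an amine, a carboxylic acid or a chlorine atom on the same carbon would give a number in this assay that stands clear of the scatter.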